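The compounds below may be only part of what the source reports. "The series", "measured", "known", "first", "only" and "open" are said of these compounds alone.

The measured compounds, each with its result in a functional assay on HT-29 cells (Homo sapiens) for cytotoxicity, read by MTT assay, with a stated time of 72 h; on this read-out higher numbers stand for weaker inhibition and lower numbers for stronger inhibition:
Compound 1 `COc1cc2c(Oc3ccc(NC(=O)c4nn(-c5ccccc5F)c(=O)c5ccccc45)cc3F)ccnc2cc1OCCCN1CCCC1` gives 400 nM.
Compound 2 `COc1cc2c(Oc3ccc(NC(=O)c4nn(-c5ccc(Br)cc5)c(=O)c5ccccc45)cc3F)ccnc2cc1OCCCN1CCCC1` gives 670 nM.
Compound 3 `COc1cc2c(Oc3ccc(NC(=O)c4nn(-c5ccc([N+](=O)[O-])cc5)c(=O)c5ccccc45)cc3F)ccnc2cc1OCCCN1CCCC1` gives 1760 nM.

Compound 2 stands second highest of these three numbers. Its nearest neighbour on the numbers is compound 1; the step of a 1.7-fold higher number from compound 1 to compound 2 (0.22 log units; within the scatter) lies within the scatter, so the two cannot be told apart. The step of a 2.6-fold higher number from compound 2 to compound 3 (0.42 log units; beyond the scatter) lies beyond the scatter, as does a 4.4-fold higher number from compound 1 to compound 3 (0.64 log units; beyond the scatter).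

Compound 4 `COc1cc2c(Oc3ccc(NC(=O)c4nn(-c5ccc(Br)cc5)c(=O)c5ccccc45)cc3F)ccnc2cc1OCCCN1CCN(C)CC1` differs from compound 2 in one place: 4-methylpiperazin-1-yl in place of pyrrolidin-1-yl on a saturated chain carbon, three bonds along the chain from an oxygen on an aromatic ring. Among the compounds with values here, none of the measured steps touches this part of the molecule. All three steps vary the group on the aromatic nitrogen, while the chain ending in pyrrolidin-1-yl is the same in compounds 1, 2 and 3. Within the data shown here, there is thus no measured step that bears on the change directly, and no basis in the data for expecting a step beyond the scatter in this assay in either direction. Compound 4 is therefore expected to give about 670 nM, with a range from 250 nM to 1800 nM. The expected step of no change at the digits printed from compound 2 to compound 4 (within the scatter) amounts to no change beyond the scatter, with a wide range to reflect the lack of any direct comparison.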

Compound 4, half-maximal inhibitory concentration: 850 nM
Compound 4: the middle estimate sits 1.3-fold (0.10 log units) below what was measured; low and high end bracket the measured number.
By their numbers in this assay, from the lowest: compounds 1, 2 and 4 (each within the scatter of the next, the first and the last beyond it); then compound 3.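

In this assay, the step of a 1.3-fold higher number from compound 2 to compound 4 (0.10 log units; within the scatter) comes from replacing pyrrolidin-1-yl with 4-methylpiperazin-1-yl, so the two compounds cannot be told apart on this read-out. Within the data shown here, this is the first information about this position, on a saturated chain carbon, three bonds along the chain from an oxygen on an aromatic ring. The earlier steps shown here changed only the group on the aromatic nitrogen. It shows that, with the 4-bromophenyl group held constant, a five-membered ring with one hetero atom can give way to a six-membered ring with two hetero atoms without a change that rises above the scatter, although no accompanying measurement offers an explanation for this result.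

Going by these compounds, it remains open whether the same exchange would behave in the same way alongside the 2-fluorophenyl group of compound 1 or the 4-nitrophenyl group of compound 3. Also unresolved is how this read-out would respond to a different group in this position, such as morpholin-4-yl, dimethylamino or a carboxylic acid, or to a shorter chain such as 2-(4-methylpiperazin-1-yl)ethyl.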